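The compounds below may be only part of what the source reports. "The series", "measured", "known", "first", "only" and "open" are said of these compounds alone.

In a toxicity assay on A549 cells (Homo sapiens) for cytotoxicity, read by luminescence and CellTiter-Glo, with a stated time of 48 h (on this read-out higher numbers stand for lower toxicity in this test and lower numbers for higher toxicity in this test), compound 1 `COCCOc1ccc(-c2nc3ncccn3c2NC2CCCCC2)cc1` gives > 100000 nM, which is a limit of the assay rather than a number. Compound 2 `CCCCOc1ccc(-c2nc3ncccn3c2NC2CCCCC2)c(C)c1` gives 32000 nM in this assay. Compound 3 `COCCOc1ccc(-c2nc3ncccn3c2Nc2ccccc2)cc1` gives > 100000 nM, again only a limit.

Compound 3 differs from compound 1 by phenyl in place of cyclohexyl on a nitrogen on an aromatic ring. The step that the two limits leave unreadable from compound 1 to compound 3 cannot be read, since both values sit at the limit of > 100000 nM in this assay, at which 2 of the 3 values shown sit. The difference between the cores of compound 1 and compound 2 is not broken down here.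

Compound 4 `CCCCOc1ccc(-c2nc3ncccn3c2Nc2ccccc2)c(C)c1` differs from compound 2 by phenyl in place of cyclohexyl on a nitrogen on an aromatic ring, the same change. Since the measured pair leaves the size of this change unknown, the step from compound 2 to compound 4 is expected to be small, about a 1.3-fold higher number from compound 2 to compound 4 (0.10 log units; within the scatter). Compound 4 is therefore estimated at 40000 nM in this assay, expected to lie between 12000 nM and 130000 nM.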

Compound 4, half-maximal cytotoxic concentration: 23000 nM
Beside the measured number, compound 4's estimate is 1.7-fold (0.24 log units) above it; measured number inside the range.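

In this assay, phenyl in place of cyclohexyl on a nitrogen on an aromatic ring gives a 1.4-fold lower number from compound 2 to compound 4 (0.14 log units; within the scatter), so on this core the two values cannot be told apart. On the core of compound 1 the same change cannot be read, since compound 1 and compound 3 each give only a limit of the assay and not a number: the limit of > 100000 nM in this assay, at which 2 of the 4 values shown sit. This leaves a single readable pair, which cannot show whether the change behaves alike on the two cores.

The compounds shown leave open how a group other than cyclohexyl or phenyl on that nitrogen, such as a longer chain or one ending in an amine or a carboxylic acid, would read in this assay. They also leave open how far each difference between the cores of compound 1 and compound 2 contributes on its own.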